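The source may report more compounds than this note shows. Statements on the series, on what has been measured and on what is new or still open speak of the compounds shown alone.

Measured compounds in a functional assay on K562 cells (Homo sapiens) for cytotoxicity, read by MTT assay, with a stated time of 72 h; a higher number here means a weaker inhibitor, a lower number a stronger inhibitor:

Compound 1, `C=C1C(=O)[C@@]23C(=O)OC[C@]4(C(=O)CCC(C)(C)[C@H]4C=O)[C@@H]2CC[C@@H]1[C@H]3OC(C)=O`: 1390 nM
Compound 2, `C=C1C(=O)[C@@]23C(=O)OC[C@]4(C(=O)CCC(C)(C)[C@H]4C=O)[C@@H]2CC[C@@H]1[C@H]3OC(=O)c1ccc(C(F)(F)F)cc1`: 2820 nM
Compound 3, `C=C1C(=O)[C@@]23C(=O)OC[C@]4(C(=O)CCC(C)(C)[C@H]4C=O)[C@@H]2CC[C@@H]1[C@H]3OC(=O)c1ccc([N+](=O)[O-])cc1`: 1330 nM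

Compound 1 carries the acetoxy group on the shared core and sits second highest of the three numbers in this assay; compound 3 is within the scatter of it, while compound 2 lies beyond the scatter on the higher side.

Compound 4, `C=C1C(=O)[C@@]23C(=O)OC[C@]4(C(=O)CCC(C)(C)[C@H]4C=O)[C@@H]2CC[C@@H]1[C@H]3OC(=O)c1ccc(Cl)cc1`, is the next member. Its difference from compound 1 is counted as follows:
4-chlorophenyl in place of methyl on a carbonyl carbon
Cut one bond further out, the acetyl of compound 1 becomes a (4-chlorophenyl)carbonyl in compound 4.

Among the measured compounds shown here, two measured steps bear on this change, since both replace the same methyl on the carbonyl carbon with a substituted phenyl: a 2.0-fold higher number from compound 1 to compound 2 (0.31 log units; beyond the scatter) and a 1.0-fold lower number from compound 1 to compound 3 (0.02 log units; within the scatter). The third step, a 2.1-fold lower number from compound 2 to compound 3 (0.33 log units; beyond the scatter), shows that swapping one para substituent for another moves the number by a modest amount only. Taken together, an aryl in place of methyl at this carbonyl carbon has produced either no step beyond the scatter or a modest rise in the number, and nothing larger. For compound 4 a number close to compound 1 or somewhat higher is therefore expected, with no step beyond the scatter as the most likely outcome and a modest rise as the alternative.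

The step expected from compound 1 to compound 4 in this assay is a 1.3-fold higher number from compound 1 to compound 4 (0.11 log units; within the scatter). Compound 4 is estimated at 1800 nM in this assay, with a range from 900 nM to 3600 nM.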

Compound 4, half-maximal inhibitory concentration: 1380 nM
Compound 4: the middle estimate sits 1.3-fold (0.12 log units) above what was measured; the measured number falls inside the stated range.
By their numbers in this assay, from the lowest: compounds 3, 4 and 1 (each within the scatter of the next); then compound 2.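

In this assay, the step of a 1.0-fold lower number from compound 1 to compound 4 (0.00 log units; within the scatter) shows that 4-chlorophenyl in place of methyl on this carbonyl carbon leaves the number unchanged within the scatter, so compound 3 is no longer the only aryl ester level with the acetyl compound. Changing only the group on the aromatic carbon gives a 1.0-fold higher number from compound 3 to compound 4 (0.02 log units; within the scatter) for chloro in place of nitro, but a 2.0-fold lower number from compound 2 to compound 4 (0.31 log units; beyond the scatter) for chloro in place of trifluoromethyl, which leaves compounds 1, 3 and 4 within the scatter of one another and makes compound 2, the trifluoromethyl ester, the one exception to that grouping. The compounds carry no accompanying measurement that would account for this exception.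

Open, going by these compounds, is whether an amine or a carboxylic acid on the aromatic ring would stay within the scatter of compound 1 in this assay, or would instead follow compound 2. Also open, on these data alone, is what a longer alkyl chain in place of methyl on the carbonyl carbon, or a free hydroxyl in place of the acetoxy group, would do to the number.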